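The source may report more compounds than this note shows. Statements on the series, on what has been measured and on what is new or still open speak of the compounds shown alone.

Measured in an ADME assay on HFF cells (Homo sapiens) for cytotoxicity, with a stated time of 8 days; on this read-out lower numbers stand for higher toxicity in this test and higher numbers for lower toxicity in this test:
- compound 1 `Nc1nc(OCc2ccccc2)c2ncn(/C=C3/CC3(CO)CO)c2n1`: > 300000 nM
- compound 2 `Nc1nc(NC2CCCC2)c2ncn(/C=C3/CC3(CO)CO)c2n1`: > 300000 nM

Both values are limits of the assay, not numbers. Compound 2 stands at a limit, > 300000 nM, so no number for it is available. Within the data shown here, the position of the series so far is the limit of > 300000 nM in this assay, at which 2 of the 2 values shown sit.

Compound 3 `Nc1nc(NC2CCCCC2)c2ncn(/C=C3/CC3(CO)CO)c2n1` carries cyclohexyl in place of cyclopentyl on a nitrogen on an aromatic ring. Among the measured compounds shown here, the only measured step that bears on this change is a step that the two limits leave unreadable from compound 1 to compound 2, where cyclopentylamino replaces benzyloxy on an aromatic carbon. It offers no size to carry over. With that step unreadable, no change beyond the usual scatter is expected in this assay, and no direction can be assigned. The expected step is a number no higher from compound 2 to compound 3 (the limit leaves the size open). For compound 3 the estimated value is 300000 nM, with an expected range of 120000 nM to 600000 nM, and another limit is the likely report.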

Compound 3, half-maximal cytotoxic concentration: > 300000 nM
Compound 3 ended at the assay's limit; the forecaster's own chance of this, stated with the estimate: 85%; the middle value sits exactly at the limit.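

In this assay, among these compounds, no step among compound 1, compound 2 and compound 3 can be read, and the series holds a single position: the limit of > 300000 nM in this assay, at which 3 of the 3 values shown sit. The compounds shown leave open whether benzyloxy, cyclopentylamino and cyclohexylamino differ at all on this read-out.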